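Ethoxy for Methyl in an Anilide Series at the Limit

The source may report more compounds than this note shows. Statements on the series, on what has been measured and on what is new or still open speak of the compounds shown alone.

Compound 2 `Cc1ccc(Cl)cc1NC(=O)CN1CCN(S(=O)(=O)N2CCC(C)CC2)CC1` and compound 1 `COc1ccc(C)cc1NC(=O)CN1CCN(S(=O)(=O)N2CCC(C)CC2)CC1` share the same core. In an assay on HEK293 cells for inhibition of potassium channel subfamily T member 1 (Homo sapiens), read by thallium flux (a lower number here means a stronger inhibitor, a higher number a weaker inhibitor), compound 2 gives only a limit, > 10000 nM. Compound 1 likewise gives a limit in this assay, > 10000 nM. The step that the two limits leave unreadable from compound 1 to compound 2 is unreadable, since (the limit of > 10000 nM in this assay, at which 2 of the 2 values shown sit). Compound 3 `CCOc1ccc(Cl)cc1NC(=O)CN1CCN(S(=O)(=O)N2CCC(C)CC2)CC1` differs from compound 2 by ethoxy in place of methyl on an aromatic carbon. Going by the values given here, no measured step bears on this change, and both measured values sit at the limit. Compound 3 is therefore expected to stay at or near that limit, with an estimated 15000 nM in this assay (range 3000 nM to 60000 nM), an expected step that the limit leaves unreadable from compound 2 to compound 3.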

Compound 3, half-maximal inhibitory concentration: 7100 nM
The estimate for compound 3 lay 2.1-fold (0.32 log units) above the measured number; measured number inside the range.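

In this assay, compound 3 is the only one of the three to give a number rather than a limit, so this position, ortho to a large group and para to a chloro group, tolerates ethoxy. Ethoxy in place of methyl gives an at least 1.4-fold lower number from compound 2 to compound 3 (0.14 log units; that floor lies within the scatter), and the full aryl change gives an at least 1.4-fold lower number from compound 1 to compound 3 (0.14 log units; that floor lies within the scatter). Both steps are only floors, and neither shows a gain beyond the scatter, set by the limit: the limit of > 10000 nM in this assay, at which 2 of the 3 values shown sit.

From the compounds shown here alone, the true size of either step stays open. So does whether propoxy or a hydroxyl group on this carbon would lower the number further.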